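The source may hold more compounds than are shown below. What is called first, only, known or untested is meant among the compounds shown, and "the series" means these compounds.

Compound 2, `O=C(/C=C/c1ccc(OCc2cn(Cc3ccccc3F)nn2)cc1)c1ccc(Br)cc1`, carries a 2-fluorophenyl on the saturated chain carbon bound to the aromatic nitrogen. In a functional assay on HepG2 cells (Homo sapiens) for inhibition, read by MTT assay, with a stated time of 48 h, tested at 10 uM (a lower number here means less inhibition of growth, a higher number more inhibition of growth at the concentration tested), compound 2 gives 29%, the top of the three numbers, yet within the scatter of both neighbours: compound 1, `O=C(/C=C/c1ccc(OCc2cn(Cc3ccc(Br)cc3)nn2)cc1)c1ccc(Br)cc1`, gives 22% in this assay, and compound 3, `O=C(/C=C/c1ccc(OCc2cn(Cc3ccc(F)cc3)nn2)cc1)c1ccc(Br)cc1`, gives 22%. The steps of a number 7 percentage points higher from compound 1 to compound 2 (within the scatter) and a number 7 percentage points lower from compound 2 to compound 3 (within the scatter) and no change at the digits printed from compound 1 to compound 3 (within the scatter) all stay within the scatter.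

Compound 4, `O=C(/C=C/c1ccc(OCc2cn(Cc3ccccc3F)nn2)cc1)c1ccc([N+](=O)[O-])cc1`, differs from compound 2 by nitro in place of bromo on an aromatic carbon. Within the data shown here, no measured step touches this end of the molecule; the nearest comparison, the halogen swap on an aromatic carbon in no change at the digits printed from compound 1 to compound 3 (within the scatter), moved nothing, and every change seen so far, wherever placed, left the growth inhibition essentially unchanged. On that basis the step to compound 4 is expected to stay within the scatter, with no change at the digits printed from compound 2 to compound 4 (within the scatter) the estimated step. Compound 4 is therefore expected to give 29% in this assay, with a likely range from 12% to 48%.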

Compound 4, percent growth inhibition at one concentration: 22%
For compound 4 the middle estimate is 7 percentage points above the measured one, within the range that was stated.
By their numbers in this assay, from the lowest: compounds 1, 3, 4 and 2 (each within the scatter of the next).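

Among these compounds, this is the first measured step at the 4-bromophenyl end of the molecule, and in this assay nitro in place of bromo on an aromatic carbon, para to a large group, gives a number 7 percentage points lower from compound 2 to compound 4 (within the scatter) with the 2-fluorophenyl group held constant. Nitro brings three heavy atoms for one and two hydrogen-bond acceptors where bromo has none, yet the two compounds cannot be told apart in this read-out. Nothing available explains this result or ties it to a property of either group.

On these data alone, whether an amine or a carboxylic acid on this aromatic carbon would give a step beyond the scatter remains open. Also open, as far as these compounds go, is whether nitro in place of bromo would read the same with the 4-bromophenyl or 4-fluorophenyl group of compound 1 and compound 3 at the other end.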